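This account rests on a few compounds, and the source may have more. Where it says the series, first, only, none or still open, it means among the compounds named here.

Compound 2 `CN1CCN(c2nc(-c3cccc(Cl)c3)nc3[nH]cnc23)CC1` has been measured in an assay on cells for displacement of a labelled ligand from adenosine receptor A3 (Homo sapiens), read by scintillation counting and radioligand binding, with a stated time of 180 min, tested at 10 uM (on this read-out lower numbers stand for less inhibition and higher numbers for more inhibition at the one concentration tested (going by the name of the read-out)), where compound 2 gives > 80%, which is a limit of the assay rather than a number. Its companion, compound 1 `Clc1cccc(-c2nc(N3CCCCC3)c3nc[nH]c3n2)c1`, is known as well: in this assay compound 1 gives > 80%, again a limit. For the measured compounds named here, the single measured step, a step that the two limits leave unreadable from compound 1 to compound 2, is therefore unreadable in size, as the limit of > 80% in this assay, at which 2 of the 2 values shown sit, shows, both values sitting at the same limit. Compound 3 `CN1CCN(c2nc(-c3ccc(O)cc3)nc3[nH]cnc23)CC1` is the compound yet to be measured, and it differs from compound 2 by 4-hydroxyphenyl in place of 3-chlorophenyl on an aromatic carbon. Going by the values given here, no measured step touches this group; the one step known concerns the 4-methylpiperazin-1-yl group instead, and even that step has no readable size, so nothing measured bears on the exchange for 4-hydroxyphenyl. Compound 3 is therefore expected, with little to lean on, to give 55% in this assay, within a range from 15% to 85%. The step that this expectation means, a number at least 25 percentage points lower from compound 2 to compound 3 (beyond the scatter), is estimated to point downward from the limit at which compound 2 stands.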

Compound 3, a percentage reported as inhibition, at one concentration (the size of the read-out at that concentration, not a potency): 48%
The estimate for compound 3 lay 7 percentage points above the measured number; the range from low to high includes it.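

With this change, the aromatic carbon between two ring nitrogen atoms becomes the first place in the series where a step can be read in this assay: 4-hydroxyphenyl in place of 3-chlorophenyl gives a number at least 32 percentage points lower from compound 2 to compound 3 (beyond the scatter). The step from compound 1 to compound 2, at the 4-methylpiperazin-1-yl group, cannot be read, so the two places cannot be ranked against each other, but the read-out is now shown to respond to the group at this carbon while the 4-methylpiperazin-1-yl group stays fixed. The printed size is only a lower bound on the drop, because compound 2 stands at a limit of the assay and not at a number: the limit of > 80% in this assay, at which 2 of the 3 values shown sit.

The exchange swaps chlorine for a hydroxyl and moves the substituent around the phenyl ring at once, so the compounds shown do not say which of the two carries the step; 4-chlorophenyl, 3-hydroxyphenyl or plain phenyl at this carbon would separate them. On these data alone, it also stays open whether the same exchange would give a like step with piperidin-1-yl in place of 4-methylpiperazin-1-yl, and how a methoxy group or an amine on the phenyl ring would fare.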